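The source may hold more compounds than are shown below. What is called first, only, known or untested is meant among the compounds shown, and "the series" means these compounds.

Of the compounds shown here, three have been measured in an assay on HEK293 cells for agonist activity at transient receptor potential cation channel subfamily M member 8 (Homo sapiens), read by fluorescence and calcium flux, with a stated time of 15 min; a lower number here means that less compound is needed, a higher number that more compound is needed for the effect. Compound 1 `CCN(Cc1cccs1)C(=O)COc1ccc(F)cc1` gives 422 nM, the highest of the three numbers. Compound 2 `CCN(Cc1cccs1)C(=O)COc1cc(C)ccc1O` gives 24 nM, and compound 3 `COc1ccc2oc(C(=O)N(Cc3cccs3)c3ccn[nH]3)cc2c1` gives 1.1 nM, the lowest of the three; both of these gaps to compound 1 lie beyond the usual scatter. Compound 4 `CCN(Cc1cccs1)C(=O)COc1ccc(Cl)cc1` is the next step from compound 1: chloro in place of fluoro on an aromatic carbon, a chloro in place of fluoro on an aromatic carbon of a six-membered aromatic ring of carbon only. Among the measured compounds shown here, no measured pair shows this exact exchange, so there is no step to lean on. A small step is expected, from compound 1 to compound 4 a 1.4-fold lower number from compound 1 to compound 4 (0.15 log units; within the scatter), possibly within the scatter. For compound 4 the estimate in this assay is 300 nM, with a range from 100 nM to 900 nM.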

Compound 4, half-maximal effective concentration: 39 nM
Compound 4: the middle estimate sits 7.7-fold (0.89 log units) above what was measured; measured number below the stated range.
By their numbers in this assay, from the lowest: compound 3; then compounds 2 and 4 (each within the scatter of the next); then compound 1.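

Chloro in place of fluoro on this aromatic carbon, para to a large group, gives an 11-fold lower number from compound 1 to compound 4 (1.03 log units; beyond the scatter) in this assay and so counts as a large step for the exchange of a single atom. Among the compounds shown here, this position therefore responds strongly to which halogen it carries, something no earlier pair could show. Nothing available explains the size of this step. From the compounds shown here alone, what bromo, a nitrile or an amine on this same carbon would give remains open. So does whether the exchange would have a similar effect on a different core.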